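This account rests on a few compounds, and the source may have more. Where it says the series, first, only, none or still open, it means among the compounds named here.

Of the compounds shown here, three have been measured in a functional assay on A549 cells (Homo sapiens) for inhibition, read by sulforhodamine B assay, with a stated time of 48 h; on this read-out lower numbers stand for stronger inhibition of growth and higher numbers for weaker inhibition of growth. Compound 1 `COC(=O)[C@@]1(C)CCC=C2[C@@H]1CC[C@@H](C)[C@]2(C)Cc1c[nH]c2c(Br)cccc12` gives 22000 nM, compound 2 `COC(=O)[C@@]1(C)CCC=C2[C@@H]1CC[C@@H](C)[C@]2(C)Cc1c(C)[nH]c2ccccc12` gives 15000 nM, and compound 3 `COC(=O)[C@@]1(C)CCC=C2[C@@H]1CC[C@@H](C)[C@]2(C)Cc1c(C)[nH]c2c(C)cccc12` gives 14000 nM, the low end of the three numbers, with both others within the scatter of it. Among the measured compounds shown here, the only single-point step measured is a 1.1-fold lower number from compound 2 to compound 3 (0.03 log units; within the scatter). Compound 4 `COC(=O)[C@@]1(C)CCC=C2[C@@H]1CC[C@@H](C)[C@]2(C)Cc1c(C)[nH]c2c(Br)cccc12` differs from compound 3 by bromo in place of methyl on an aromatic carbon. For the measured compounds named here, no measured step covers this exchange directly; compound 1 carries the bromo group without the second methyl and its value stands within the scatter of compound 3. In this assay no shift beyond the scatter is therefore expected, and the step is estimated at a 1.3-fold higher number from compound 3 to compound 4 (0.11 log units; within the scatter). For compound 4 the expected value is 18000 nM, with a range from 9000 nM to 36000 nM.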

Compound 4, concentration for 50% growth inhibition: 27000 nM
For compound 4 the middle estimate is 1.5-fold (0.18 log units) below the measured one; low and high end bracket the measured number.
By their numbers in this assay, from the lowest: compounds 3, 2, 1 and 4 (each within the scatter of the next).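

On the aromatic carbon ortho to a fused ring, bromo in place of methyl gives a 1.9-fold higher number from compound 3 to compound 4 (0.29 log units; within the scatter), and bromo in place of hydrogen gives a 1.8-fold higher number from compound 2 to compound 4 (0.26 log units; within the scatter), so hydrogen, methyl and bromo at this position show no step beyond the scatter in this assay. Methyl in place of hydrogen on an aromatic carbon now reads on a second core, with a 1.2-fold higher number from compound 1 to compound 4 (0.09 log units; within the scatter), and the two readings agree: the same change on two cores in this assay, a 1.1-fold lower number (0.03 log units; within the scatter) from compound 2 to compound 3 and a 1.2-fold higher number (0.09 log units; within the scatter) from compound 1 to compound 4, 1.3-fold (0.12 log units) apart, within the scatter of two such steps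

Open, as far as these compounds go, is whether an amine or a carboxylic acid on this aromatic carbon would give a step beyond the scatter.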